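Lengthening the ester chain on the shared core

The source may hold more compounds than are shown below. What is called first, only, known or untested is meant among the compounds shown, and "the series" means these compounds.

Compound 1 `CC(=O)O[C@H]1C(=O)OCC1(C)C`: in an assay on isolated protein for inhibition of fatty acid synthase (Mus musculus), read by spectrophotometry, using NADPH, with stated times of 30 min and 3 min, in the presence of a further agent that is not named here (on this read-out higher numbers stand for weaker inhibition and lower numbers for stronger inhibition), compound 1 gives 33200 nM
Compound 2 `CCCC(=O)O[C@H]1C(=O)OCC1(C)C`: in this assay compound 2 gives 28200 nM
Compound 3 `CCCCCCCC(=O)O[C@H]1C(=O)OCC1(C)C`: in this assay compound 3 gives 20800 nM

Compound 3 stands at the lowest of the three numbers, yet its neighbours lie within the scatter: a 1.4-fold lower number from compound 2 to compound 3 (0.13 log units; within the scatter) and a 1.6-fold lower number from compound 1 to compound 3 (0.20 log units; within the scatter), while a 1.2-fold lower number from compound 1 to compound 2 (0.07 log units; within the scatter) is likewise within the scatter. Compound 4 `CCCCCCCCCCCCCCCC(=O)O[C@H]1C(=O)OCC1(C)C` differs from compound 3 by octyl in place of hydrogen on a saturated chain carbon, seven bonds along the chain from a carbonyl carbon. Each of the three measured steps lengthens the same chain on the carbonyl side, and each gave a small lowering of the number in this assay that did not pass the scatter. None of them bears directly on octyl in place of hydrogen seven bonds along the chain, so they serve only as the nearest guide. On that guide a further small lowering in this assay is expected, possibly still within the scatter: a 1.5-fold lower number from compound 3 to compound 4 (0.17 log units; within the scatter). Compound 4 is therefore estimated at 14000 nM, within a range from 6000 nM to 35000 nM.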

Compound 4, half-maximal inhibitory concentration: 19600 nM
For compound 4 the middle estimate is 1.4-fold (0.15 log units) below the measured one; measured number inside the range.
By their numbers in this assay, from the lowest: compounds 4, 3, 2 and 1 (each within the scatter of the next).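

Octyl in place of hydrogen on a saturated chain carbon, seven bonds along the chain from a carbonyl carbon, gives a 1.1-fold lower number from compound 3 to compound 4 (0.03 log units; within the scatter) in this assay and so stays within the scatter. For the compounds shown here, this extends what the earlier compounds showed: on the shared core, the ester chain can be carried as far as in compound 4 without any measured step passing the scatter, and the added octyl does not open a step larger than that. Nothing available explains this result.

As far as these compounds go, whether a longer chain, or an amine or a carboxylic acid in place of octyl, would give a step beyond the scatter remains open. So does the effect of any change to the shared core itself, as every compound here carries it unchanged.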